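This account rests on a few compounds, and the source may have more. Where it says the series, first, only, none or still open, it means among the compounds named here.

Three stereoisomers of one small ring acid have been tested. In an assay on isolated protein for inhibition of cytosolic endo-beta-N-acetylglucosaminidase (Homo sapiens), tested at 1000 uM (a lower number here means less inhibition, a higher number more inhibition at the concentration tested (going by the name of the read-out)), compound 1 `O=C(O)[C@@H]1NC[C@@H](O)[C@@H](O)[C@H]1O` gives 26%, compound 2 `O=C(O)[C@@H]1NC[C@H](O)[C@@H](O)[C@@H]1O` gives 5.4%, and compound 3 `O=C(O)[C@@H]1NC[C@H](O)[C@H](O)[C@H]1O` gives 39%, the highest of the three. The measured steps are all changes of configuration alone: a number 20.6 percentage points lower from compound 1 to compound 2 (beyond the scatter), a number 13 percentage points higher from compound 1 to compound 3 (beyond the scatter) and a number 33.6 percentage points higher from compound 2 to compound 3 (beyond the scatter). Compound 4 `O=C(O)[C@@H]1NC[C@@H](O)[C@H](O)[C@H]1O` is the next isomer; (the two compounds have the same atoms and bonds and differ only in configuration as drawn: 1 of 4 stereo elements differ; a stereocentre at a saturated ring carbon is drawn S in compound 3 and R in compound 4). Since each measured step turned two stereocentres and moved the read-out by a modest to large amount, a single turn is expected to move it by less, most likely downward from compound 3. The step from compound 3 to compound 4 is estimated at a number 9 percentage points lower from compound 3 to compound 4 (within the scatter). Compound 4 is therefore expected to give about 30%, within a range from 10% to 50%.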

Compound 4, a percentage reported as inhibition, at one concentration (the size of the read-out at that concentration, not a potency): 50%
Compound 4: the middle estimate sits 20 percentage points below what was measured; low and high end bracket the measured number.
By their numbers in this assay, from the lowest: compound 2; then compound 1; then compound 3; then compound 4.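

In this assay, within the data shown here, the earlier steps each turned two stereocentres, whereas here a single turned stereocentre is enough to shift the read-out, with a number 11 percentage points higher from compound 3 to compound 4 (beyond the scatter) and with a number 24 percentage points higher from compound 1 to compound 4 (beyond the scatter) as well. Turning three stereocentres gives a number 44.6 percentage points higher from compound 2 to compound 4 (beyond the scatter) and completes the picture, since compound 4 now stands highest of the four isomers. All of this remains inhibition at one concentration, not a potency. Still open, as far as these compounds go, is whether an amide or a methyl ester in place of the carboxylic acid keeps this inhibition, and whether a longer chain on the core changes it.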